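A few compounds are considered here, and "the series" means these few. Any claim that something is new, unique, unknown or untested is made for them only; others in the source may bear on it.

Compound 1 `O=C(N/N=C/c1ccccc1)c1cn(C2CC2)c2cc(N3CCNCC3)c(F)cc2c1=O` measures 25000 nM here.
Compound 2 `COc1ccc(/C=N/NC(=O)c2cn(C3CC3)c3cc(N4CCNCC4)c(F)cc3c2=O)cc1O` measures 25000 nM here.

Compound 1 sits at 25000 nM in a functional assay on L1210 cells (Mus musculus) for cytotoxicity, read by MTT assay (on this read-out lower numbers stand for stronger inhibition and higher numbers for weaker inhibition), and is level with compound 2, its nearest neighbour on these numbers. The next compound to be tested is compound 3 `O=C(N/N=C/c1ccccc1O)c1cn(C2CC2)c2cc(N3CCNCC3)c(F)cc2c1=O`, which carries 2-hydroxyphenyl where compound 1 carries phenyl. The change is hydroxy in place of hydrogen on an aromatic carbon, ortho to a large group.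

For the measured compounds named here, only one measured step bears on this change. Putting 3-hydroxy-4-methoxyphenyl in place of phenyl gave no change at the digits printed from compound 1 to compound 2 (within the scatter) in this assay and so left no measurable mark. That group also holds a hydroxy, though 2-hydroxyphenyl is a different group, and a single step is thin evidence. No step beyond the scatter is therefore expected, in either direction, and the range is kept wide. The step expected is a 1.1-fold lower number from compound 1 to compound 3 (0.06 log units; within the scatter) on this reasoning. For compound 3 the estimate is 22000 nM, with an expected range from 7000 nM to 50000 nM in this assay.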

Compound 3, half-maximal inhibitory concentration: 25000 nM
The estimate for compound 3 lay 1.1-fold (0.06 log units) below the measured number; measured number inside the range.
By their numbers in this assay, from the lowest: compounds 1, 2 and 3 (each within the scatter of the next).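

In this assay, hydroxy in place of hydrogen on an aromatic carbon, ortho to a large group, gave no change at the digits printed from compound 1 to compound 3 (within the scatter) and so left no measurable mark. This gives the position a direct reading of its own, whereas the earlier pair offered only 3-hydroxy-4-methoxyphenyl, a group that differs from phenyl in more than one place. Exchanging that group for 2-hydroxyphenyl gave no change at the digits printed from compound 2 to compound 3 (within the scatter) as well, so phenyl, 2-hydroxyphenyl and 3-hydroxy-4-methoxyphenyl all stand level in this assay on the shared core.

The compounds shown leave open whether any group on this ring can shift the number beyond the scatter, and an amine, a carboxylic acid or a longer chain such as butoxy at the same place would be a sharper test than hydroxy. Nothing available here gives any reason why these three compounds stand level.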